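The compounds below may be only part of what the source reports. "The series", "measured", "known", "first", "only" and "open" are said of these compounds alone.

Compound 1 `NC(=O)c1c(NC(=O)c2ccccc2Cl)sc2c1CCNC2`, compound 2 `NC(=O)c1c(NC(=O)c2ccccc2Cl)sc2c1CCN(Cc1ccccc1F)C2` and compound 3 `NC(=O)c1c(NC(=O)c2ccccc2Cl)sc2c1CCN(C(=S)Nc1cccc3ccccc13)C2` share one core and were tested in a functional assay on HeLa cells (Homo sapiens) for antiproliferative activity, with a stated time of 24 h; on this read-out lower numbers stand for stronger inhibition and higher numbers for weaker inhibition. In this assay compound 1 gives 45000 nM, and compound 3 gives 30800 nM, a number within the scatter of compound 1. For compound 2 only a limit is known, > 50000 nM, and that limit is the limit of > 50000 nM in this assay, at which 1 of the 3 values shown sits. Among the compounds with values here, the one measured step, an at least 1.1-fold higher number from compound 1 to compound 2 (0.04 log units; that floor lies within the scatter), concerns the amine nitrogen in the ring. Compound 4 `NC(=O)c1c(NC(=O)c2ccccc2Cl)sc2c1CCN(C(=S)Nc1ccccc1F)C2` differs from compound 3 elsewhere: 2-fluorophenyl in place of naphthalen-1-yl on an amide-type nitrogen. Within the data shown here, no measured step covers this change, so a step within the scatter is expected. The expected step of a 1.1-fold higher number from compound 3 to compound 4 (0.06 log units; within the scatter) is accordingly small. Compound 4 is estimated at 35000 nM, between 15000 nM and 50000 nM.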

Compound 4, half-maximal inhibitory concentration: 28700 nM
Beside the measured number, compound 4's estimate is 1.2-fold (0.09 log units) above it; low and high end bracket the measured number.
By their numbers in this assay, from the lowest: compounds 4, 3 and 1 (each within the scatter of the next). At a limit, above all of these: compound 2.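

In this assay, 2-fluorophenyl in place of naphthalen-1-yl on the amide-type nitrogen gives a 1.1-fold lower number from compound 3 to compound 4 (0.03 log units; within the scatter), so losing one aromatic ring and adding fluorine leaves no readable change at this position. The whole group on the amine nitrogen in the ring, set against a hydrogen atom, also stays small: a 1.6-fold lower number from compound 1 to compound 4 (0.20 log units; within the scatter). The step that starts from a limit reads an at least 1.7-fold lower number from compound 2 to compound 4 (0.24 log units; that floor lies within the scatter), which is only a floor.

Still open, as far as these compounds go, is whether plain phenyl would separate the effect of the fluorine from that of the lost ring. Also open, from the compounds shown here alone, is whether an aryl group carrying an amine or a carboxylic acid at this position would move the number beyond the scatter.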